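This account rests on a few compounds, and the source may have more. Where it says the series, first, only, none or still open, it means among the compounds named here.

Compound 1 (`OC[C@H]1O[C@@H](n2cnc3c(NCc4cccc(Br)c4)ncnc32)[C@H](O)[C@@H]1O`) reads > 166000 nM in an ADME assay on NIH3T3 cells (Mus musculus) for cytotoxicity, with a stated time of 72 h (a lower number here means a stronger inhibitor, a higher number a weaker inhibitor), and this is a limit of the assay, not a number. Compound 2 (`COc1cc(CNc2ncnc3c2ncn3[C@@H]2O[C@H](CO)[C@@H](O)[C@H]2O)cc(OC)c1`) gives "not determined" (no result reported). Compound 3 (`OC[C@H]1O[C@@H](n2cnc3c(NCc4ccc(F)c(F)c4F)ncnc32)[C@H](O)[C@@H]1O`) gives "not determined" (no result reported), so it has no number of its own to stand on. Compound 4 (`OC[C@H]1O[C@@H](n2cnc3c(NCc4ccc(F)c(Cl)c4)ncnc32)[C@H](O)[C@@H]1O`) is still to be measured. The structural step is 3-chloro-4-fluorophenyl in place of 2,3,4-trifluorophenyl on a saturated chain carbon bound to a nitrogen on an aromatic ring. The only reference is the limit held by compound 1, (the limit of > 166000 nM in this assay, at which 1 of the 3 values shown sits), so no shift beyond the scatter, in either direction, is expected in this assay. For compound 4 the estimated value is 170000 nM, with an expected range of 60000 nM to 350000 nM.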

Compound 4, half-maximal inhibitory concentration: > 166000 nM
Compound 4: no number, only a limit; the forecaster's own chance of this, stated with the estimate: 75%; the middle value does not contradict the limit.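

Compound 1 and compound 4 both stand at a limit of the assay in this assay, not at a number, so no step can be read between them. The compounds shown leave open whether changing the substituted phenyl group on the shared core moves this read-out at all.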